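Benzyl substituent variation and cytotoxicity in the series

The compounds below may be only part of what the source reports. "The series", "measured", "known", "first", "only" and "open" are said of these compounds alone.

Compound 3 `Cc1cc(C)c(Oc2cc(Nc3ccc(C#N)cc3)ncc2C(=O)NCc2cn(Cc3ccc([N+](=O)[O-])cc3)nn2)c(C)c1` gives in an ADME assay on MT4 cells (Homo sapiens) for cytotoxicity, read by MTT assay, with a stated time of 5 days (on this read-out higher numbers stand for lower toxicity in this test and lower numbers for higher toxicity in this test), only a limit, >= 139000 nM. Compound 1 `Cc1cc(C)c(Oc2cc(Nc3ccc(C#N)cc3)ncc2C(=O)NCc2cn(Cc3ccccc3Cl)nn2)c(C)c1` likewise sits at a limit, >= 188000 nM. Compound 2 `Cc1cc(C)c(Oc2cc(Nc3ccc(C#N)cc3)ncc2C(=O)NCc2cn(Cc3cccc(Cl)c3)nn2)c(C)c1` gives 187000 nM. The steps of a number no higher from compound 1 to compound 2 (the limit leaves the size open), a step that the two limits leave unreadable from compound 1 to compound 3 and a step that the limit leaves unreadable from compound 2 to compound 3 are accordingly unreadable in size, as the limit of >= 139000 nM in this assay, at which 1 of the 3 values shown sits, and the limit of >= 188000 nM in this assay, at which 1 of the 3 values shown sits, show. Compound 4 `Cc1cc(C)c(Oc2cc(Nc3ccc(C#N)cc3)ncc2C(=O)NCc2cn(Cc3ccccc3C)nn2)c(C)c1` differs from compound 3 by 2-methylphenyl in place of 4-nitrophenyl on a saturated chain carbon bound to an aromatic nitrogen. Going by the values given here, no measured step resolves this change, and all three measured benzyl variants sit at or close to a limit, so no step beyond the scatter is expected in this assay, with a step that the limit leaves unreadable from compound 3 to compound 4 as the expected change. Compound 4 is estimated at 180000 nM, in a range from 90000 nM to 360000 nM, and is expected most likely to be reported again as a limit.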

Compound 4, half-maximal cytotoxic concentration: >= 164000 nM
Compound 4 gave a limit, no number; the forecaster's own chance of this, stated with the estimate: 70%; the middle value does not contradict the limit.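

Compound 4 gives only a limit, >= 164000 nM. The steps to it from compound 1, compound 2 and compound 3 cannot be read. The compounds shown leave open whether these benzyl variants differ at all in cytotoxicity.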